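The compounds below may be only part of what the source reports. "The series", "measured", "known", "first", "only" and "open" are said of these compounds alone.

Two compounds of the series have numbers in an assay on isolated protein for inhibition of P-selectin glycoprotein ligand 1 (Homo sapiens), read by surface plasmon resonance, tested at 250 uM; a lower number here means less inhibition, a higher number more inhibition at the concentration tested (going by the name of the read-out). Compound 1 `CC(c1ccccc1)c1nc2c(C(F)(F)F)cccc2c(C(=O)O)c1O` gives 50%, and compound 2 `CC(Cc1nc2c(C(F)(F)F)cccc2c(C(=O)O)c1O)c1ccccc1` gives 46%. Within the data shown here, compound 2 sits alongside compound 1 on these numbers; the one measured step, a number 4 percentage points lower from compound 1 to compound 2 (within the scatter), is within the scatter. Compound 3 `O=C(O)c1c(O)c(C2(c3ccsc3)CC2)nc2c(C(F)(F)F)cccc12` differs from compound 2 by 1-(thiophen-3-yl)cyclopropyl in place of 2-phenylpropyl on an aromatic carbon. Among the measured compounds shown here, no measured step covers this exchange; the only step known concerns a different change and was small. For compound 3 the expected step is therefore a number 1 percentage points lower from compound 2 to compound 3 (within the scatter), not beyond the scatter. Compound 3 is estimated at 45%, between 25% and 65%.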

Compound 3, a percentage reported as inhibition, at one concentration (the size of the read-out at that concentration, not a potency): 7%
The estimate for compound 3 lay 38 percentage points above the measured number, outside the stated range (below it).
By their numbers in this assay, from the lowest: compound 3; then compounds 2 and 1 (each within the scatter of the next).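

The position next to the ring nitrogen is not indifferent to its substituent: in this assay, 1-(thiophen-3-yl)cyclopropyl in place of 2-phenylpropyl gives a number 39 percentage points lower from compound 2 to compound 3 (beyond the scatter), and in place of 1-phenylethyl gives a number 43 percentage points lower from compound 1 to compound 3 (beyond the scatter). Exchange between the two phenyl-bearing groups had stayed within the scatter, so only this change shows that the group here can move the number. No available data explain the drop. The thiophene and the cyclopropyl enter together, leaving open which of them goes with the step. A 1-phenylcyclopropyl group would separate the two.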